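Removing a Methyl from the Outer Ring of a Thiazolidinedione

The source may report more compounds than this note shows. Statements on the series, on what has been measured and on what is new or still open speak of the compounds shown alone.

Compound 1, `O=C1NC(=O)C(Cc2ccc(Oc3cc(C(F)(F)F)ccn3)cc2)S1`, gives 237 nM in a functional assay for agonist activity at Free fatty acid receptor 1 (Homo sapiens), read by FLIPR, in the presence of a further agent that is not named here; on this read-out lower numbers stand for an effect already at smaller amounts and higher numbers for an effect only at larger amounts of compound.
Compound 2, `Cc1cc(C(F)(F)F)cc(Oc2ccc(CC3SC(=O)NC3=O)cc2)n1`, gives 218 nM in this assay.
Compound 3, `Cc1cc(C)cc(Oc2ccc(CC3SC(=O)NC3=O)cc2)c1`, gives 96 nM in this assay.

Compound 3 has the lowest of the three numbers, and both other compounds stand beyond the scatter from it. Compound 2 and compound 1 share one core, and the step between them is a 1.1-fold higher number from compound 2 to compound 1 (0.04 log units; within the scatter); the change is hydrogen in place of methyl on an aromatic carbon. The core of compound 3 differs from that of compound 2, and that difference is not broken down here.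

Compound 4, `Cc1cccc(Oc2ccc(CC3SC(=O)NC3=O)cc2)c1`, has not yet been measured in this assay. It is made from compound 3 by hydrogen in place of methyl on an aromatic carbon. This is the same kind of change as from compound 2 to compound 1, but not the same: in compound 2 the methyl leaves a six-membered aromatic ring with 1 nitrogen, next to the ring nitrogen and meta to a trifluoromethyl group, while in compound 3 it leaves a six-membered aromatic ring of carbon only, meta to a methyl group.

Within the data shown here, the only measured example of this kind of change, a 1.1-fold higher number from compound 2 to compound 1 (0.04 log units; within the scatter), lies within the scatter. On that basis the step from compound 3 to compound 4 is expected to be about as small, roughly a 1.1-fold higher number from compound 3 to compound 4 (0.06 log units; within the scatter) in this assay. Compound 4 is therefore expected to give about 110 nM, most likely between 50 nM and 250 nM.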

Compound 4, half-maximal effective concentration: 203 nM
For compound 4 the middle estimate is 1.8-fold (0.27 log units) below the measured one; low and high end bracket the measured number.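

In this assay, putting hydrogen in place of the methyl on the carbon-only ring gives a 2.1-fold higher number from compound 3 to compound 4 (0.33 log units; beyond the scatter), a modest step, while the same change on the other core stayed within the usual scatter. Read alone, the two steps might suggest that the change matters on one core and not on the other, but the gap between them is no larger than two such steps can show by chance, so the data give no sign that the core alters the effect of this change: the same change on two cores in this assay, a 1.1-fold higher number (0.04 log units; within the scatter) from compound 2 to compound 1 and a 2.1-fold higher number (0.33 log units; beyond the scatter) from compound 3 to compound 4, 1.9-fold (0.29 log units) apart, within the scatter of two such steps. This does not show that the change has the same effect on both cores, since a real difference of this size cannot be told from scatter, and two pairs of compounds are too few to set a rule for any further core in the series.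

The compounds shown leave open how an ethyl group, an amine or a carboxylic acid in the place of this methyl would compare with methyl and hydrogen. They also leave open whether putting hydrogen in place of the methyl still carried by compound 4 would give a step of similar size.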